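This account rests on a few compounds, and the source may have more. Where it says the series, first, only, none or still open, it means among the compounds named here.

Measured compounds in a functional assay on NCI-H522 cells (Homo sapiens) for inhibition, read by sulforhodamine B assay, with a stated time of 48 h; on this read-out lower numbers stand for higher toxicity in this test and higher numbers for lower toxicity in this test:
- compound 1, `Nc1cc(N)c2nc(-c3ccccc3)c(Oc3ccc(Cl)c(Cl)c3)nc2c1`: its value, < 100000 nM, is a limit of the assay and not a number; see (the limit of < 100000 nM in this assay, at which 1 of the 3 values shown sits).
- compound 2, `Nc1cc(N)c2nc(-c3ccccc3)c(NCc3ccc(Cl)c(Cl)c3)nc2c1`: compound 2 gives 22400 nM.
- compound 3, `COc1ccc(CNc2nc3cc(N)cc(N)c3nc2-c2ccccc2)cc1OC`: compound 3 gives 63100 nM.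

Compound 3 stands at the highest of the two numbers in this assay; its nearest neighbour is compound 2, and the step of a 2.8-fold higher number from compound 2 to compound 3 (0.45 log units; beyond the scatter) is beyond the scatter. The third value, that of compound 1, is a limit only.

Compound 4, `COc1cc(CNc2nc3cc(N)cc(N)c3nc2-c2ccccc2)cc(OC)c1OC`, differs from compound 3 in one place: methoxy in place of hydrogen on an aromatic carbon.

Among the measured compounds shown here, only one measured step exists, a 2.8-fold higher number from compound 2 to compound 3 (0.45 log units; beyond the scatter), which swapped the whole aryl group rather than adding a single methoxy; no measured pair isolates the effect of a further methoxy on the ring already bearing two. It gives no direct guide, so the expected step in this assay from compound 3 to compound 4 is small, if anything a modest rise toward the assay ceiling. The estimated step is a 1.2-fold higher number from compound 3 to compound 4 (0.08 log units; within the scatter). Compound 4 is expected to give about 75000 nM in this assay, within a range from 30000 nM to 160000 nM.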

Compound 4, concentration lethal to 50% of the cells: < 50200 nM
Compound 4: a limit, no number (the forecaster's own chance of this, stated with the estimate: 35%); at least 1.4-fold (0.17 log units) between middle value and limit.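

In this assay compound 4 gives < 50200 nM, a limit of the assay and not a number. Methoxy in place of hydrogen on this aromatic carbon, ortho to a methoxy group and meta to a large group, gives an at least 1.2-fold lower number from compound 3 to compound 4 (0.09 log units; that floor lies within the scatter), the first step in the series that changes this ring in a single small group and not the whole aryl group. The step points toward a lower number, but it fixes only a floor, and its true size stays unknown because the read-out ends in a limit: the limit of < 50200 nM in this assay, at which 1 of the 4 values shown sits.

Still open, on these data alone, is how far compound 4 really lies from compound 3 in this assay. Also open, as far as these compounds go, is whether a hydroxyl, an amine or a longer alkoxy chain on the same aromatic carbon would move the number in the same direction.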